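Hydroxycarbamoyl to carboxy: working notes on compound 4

The source may hold more compounds than are shown below. What is called first, only, known or untested is meant among the compounds shown, and "the series" means these compounds.

Measured in a functional assay on CLL cells (Homo sapiens) for cytotoxicity, read by MTT assay, with a stated time of 48 h; on this read-out higher numbers stand for an effect only at larger amounts of compound and lower numbers for an effect already at smaller amounts:
- Compound 1 `C=C(CC)C(=O)c1ccc(OCC(=O)NCCCN2CCCC2=O)c(Cl)c1Cl` gives 13800 nM
- Compound 2 `C=C(CC)C(=O)c1ccc(OCC(=O)Nc2ccc(O)c([N+](=O)[O-])c2)c(Cl)c1Cl` gives 7400 nM
- Compound 3 `C=C(CC)C(=O)c1ccc(OCC(=O)Nc2ccc(/C=C/C(=O)NO)cc2)c(Cl)c1Cl` gives 2600 nM

Compound 3 holds the lowest number of the three in this assay, and its gaps to compound 2 and to compound 1 both lie beyond the usual scatter. Compound 4 `C=C(CC)C(=O)c1ccc(OCC(=O)Nc2ccc(/C=C/C(=O)O)cc2)c(Cl)c1Cl` has not yet been measured. Going from compound 3 to compound 4, hydroxy stands in place of hydroxyamino on a carbonyl carbon (hydroxy in place of hydroxyamino on a carbonyl carbon), so that 2-(hydroxycarbamoyl)ethenyl becomes 2-carboxyethenyl.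

Within the data shown here, no measured pair isolates this change, so the expectation rests on limited evidence. Among the measured compounds shown here, compound 3 at 2600 nM is the only measured member with hydroxycarbamoyl, while compound 2 at 7400 nM and compound 1 at 13800 nM lack that group and show higher numbers. A move towards the level of compound 2 is therefore expected in this assay. The expected size is a 2.7-fold higher number from compound 3 to compound 4 (0.43 log units; beyond the scatter), an estimated rise that would most likely lie beyond the scatter. For compound 4 the estimated value is 7000 nM, with an expected range from 3000 nM to 18000 nM in this read-out.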

Compound 4, half-maximal effective concentration: 3000 nM
For compound 4 the middle estimate is 2.3-fold (0.37 log units) above the measured one, within the range that was stated.
By their numbers in this assay, from the lowest: compounds 3 and 4 (each within the scatter of the next); then compounds 2 and 1 (each within the scatter of the next).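

In this assay, hydroxy in place of hydroxyamino on a carbonyl carbon gives a 1.2-fold higher number from compound 3 to compound 4 (0.06 log units; within the scatter), so this pair, the first in the series to isolate the change, does not separate the two groups at this place. Among these compounds, compound 3 was previously the only member carrying hydroxycarbamoyl, which left open whether its value depended on that group, and this pair shows that hydroxycarbamoyl can give way to carboxy without a change beyond the scatter. No data of any other kind bear on this result, so the pair says nothing about why the two groups read alike.

A methyl ester or a primary amide on the same carbonyl carbon would show whether this place also accepts groups other than hydroxy and hydroxyamino, or whether the pair's agreement is limited to these two. The compounds shown also leave open what the double-bonded chain contributes, which a saturated two-carbon chain carrying the same carboxy group would test directly.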